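The compounds below may be only part of what the source reports. "The series", "measured", "known", "first", "only" and "open" are said of these compounds alone.

Among the compounds with values here, in an ADME assay for permeability, using PAMPA, at pH 7.4 (on this read-out lower numbers stand for lower permeability and higher numbers for higher permeability), compound 2 (`CSc1ccc(NC(=O)Nc2cc(C)nc3ccccc23)cc1`) gives 473 10^-6 cm/s as the higher of the two numbers so far, and compound 1 (`Cc1cc(NC(=O)Nc2ccc(C(C)(C)C)cc2)c2ccccc2n1`) gives 142 10^-6 cm/s as the lower. Compound 3 (`CCc1ccc(NC(=O)Nc2cc(C)nc3ccccc23)cc1`) is still unmeasured. It carries ethyl in place of methylsulfanyl on an aromatic carbon, para to a large group (ethyl in place of methylsulfanyl on an aromatic carbon). Within the data shown here, only one measured step bears on this change: a 3.3-fold higher number from compound 1 to compound 2 (0.52 log units; beyond the scatter) on going to methylsulfanyl in place of tert-butyl, modest and beyond the scatter. Ethyl itself has no measured precedent in the series, so that step is a rough guide only. On that basis, a move to a lower number is expected, smaller than a 3.3-fold higher number from compound 1 to compound 2 (0.52 log units; beyond the scatter) and possibly within the scatter. The expected step is a 1.6-fold lower number from compound 2 to compound 3 (0.20 log units; within the scatter) in this read-out. For compound 3 the estimate is 300 10^-6 cm/s with an expected range of 130 10^-6 cm/s to 650 10^-6 cm/s in this assay as measured here.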

Compound 3, apparent permeability: 535 10^-6 cm/s
The estimate for compound 3 lay 1.8-fold (0.25 log units) below the measured number; measured number inside the range.
By their numbers in this assay, from the lowest: compound 1; then compounds 2 and 3 (each within the scatter of the next).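

In this assay, the exchange of methylsulfanyl for ethyl on this aromatic carbon, para to a large group, does not separate the two groups (a 1.1-fold higher number from compound 2 to compound 3 (0.05 log units; within the scatter)), so the sulfur and the hydrogen-bond acceptor counted for methylsulfanyl leave no readable mark here. The ethyl compound also stands clear of the tert-butyl compound (a 3.8-fold higher number from compound 1 to compound 3 (0.58 log units; beyond the scatter)), which makes compound 1 the lowest of the three, with compounds 2 and 3 both beyond the scatter from it and none of the three going against this. Nothing measured on these compounds explains either step.

Still open, as far as these compounds go, is whether a longer chain such as propyl stays level with ethyl at this position or moves toward tert-butyl. An amine or a carboxylic acid here remains a separate question, since every group shown carries no net charge.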